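Swapping the halogen-bearing ring on the amide of compound 1

The compounds below may be only part of what the source reports. "The series", "measured", "known", "first", "only" and "open" are said of these compounds alone.

Measured compounds:
- compound 1 `CCN1CCN(c2cc(C)c3cc(NC(=O)c4ccccc4F)ccc3n2)CC1`: 32600 nM
- compound 2 `CCN1CCN(c2cc(C)c3cc(NC(=O)c4cccc(Cl)c4)ccc3n2)CC1`: 3820 nM
- compound 3 `CCN1CCN(c2cc(C)c3cc(NC(=O)c4ccccc4OC)ccc3n2)CC1`: 13200 nM

In a functional assay on MCF7 cells (Homo sapiens) for antiproliferative activity, read by MTT assay, with a stated time of 72 h (on this read-out lower numbers stand for stronger inhibition and higher numbers for weaker inhibition), compound 1 gives the highest of the three numbers, that is the weakest inhibition; compound 3 sits nearer to it, compound 2 furthest away. The unmeasured compound 4 `CCN1CCN(c2cc(C)c3cc(NC(=O)c4ccc(Br)cc4)ccc3n2)CC1` differs from compound 1 in one place: 4-bromophenyl in place of 2-fluorophenyl on a carbonyl carbon. The step that bears most on this is an 8.5-fold lower number from compound 1 to compound 2 (0.93 log units; beyond the scatter), which also exchanges the 2-fluorophenyl for a halogen-bearing ring; the smaller shift a 2.5-fold lower number from compound 1 to compound 3 (0.39 log units; beyond the scatter) shows that any move away from 2-fluorophenyl has so far lowered the number. A lower number is therefore expected for compound 4, roughly a 6.5-fold lower number from compound 1 to compound 4 (0.81 log units; beyond the scatter). The estimate for compound 4 is 5000 nM, ranging from 1500 nM to 16000 nM.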

Compound 4, half-maximal inhibitory concentration: 5940 nM
The estimate for compound 4 lay 1.2-fold (0.07 log units) below the measured number; measured number inside the range.
By their numbers in this assay, from the lowest: compounds 2 and 4 (each within the scatter of the next); then compound 3; then compound 1.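

In this assay, 4-bromophenyl on this carbonyl carbon gives a 5.5-fold lower number from compound 1 to compound 4 (0.74 log units; beyond the scatter) and a 2.2-fold lower number from compound 3 to compound 4 (0.35 log units; beyond the scatter), so a third replacement of 2-fluorophenyl also lowers the number. Against 3-chlorophenyl the result is a 1.6-fold higher number from compound 2 to compound 4 (0.19 log units; within the scatter), which leaves these two halogen-bearing rings indistinguishable here. No measurement shown explains these shifts.

From the compounds shown here alone, compound 2 and compound 4 differ in both the halogen and where it sits, so the contribution of each remains open. Also open, going by these compounds, is how a plain phenyl, or a ring carrying an amine or a carboxylic acid, would compare.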